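Dihydroxyphenyl for dinitrophenyl in a sulfonamide urea series

The source may hold more compounds than are shown below. What is called first, only, known or untested is meant among the compounds shown, and "the series" means these compounds.

Measured so far:
Compound 1, `O=C(NCCNS(=O)(=O)c1ccc(-c2ccccc2Oc2ccc(O)c(O)c2)s1)Nc1cc(Cl)cc(Cl)c1`, gives > 20000 nM in a functional assay on HeLa cells (Homo sapiens) for inhibition, read by CCK-8 assay, with a stated time of 48 h; a lower number here means a stronger inhibitor, a higher number a weaker inhibitor.
Compound 2, `O=C(NCCNS(=O)(=O)c1ccc(-c2ccccc2Oc2ccc([N+](=O)[O-])c([N+](=O)[O-])c2)s1)Nc1cc(Cl)cc(Cl)c1`, gives > 20000 nM in this assay.
Compound 3, `O=C(NCCNS(=O)(=O)c1ccc(-c2ccccc2Oc2ccc([N+](=O)[O-])c([N+](=O)[O-])c2)s1)Nc1cc(C(F)(F)F)cc(C(F)(F)F)c1`, gives > 50000 nM in this assay.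

Each of these three values is a limit of the assay rather than a number. The value of compound 1 is a limit. The value of compound 2 is a limit. The value of compound 3 is a limit, set at a different point of the range than the other two.

One pair differs in a single place: compound 2 and compound 1, where the change is 3,4-dihydroxyphenyl in place of 3,4-dinitrophenyl on an oxygen on an aromatic ring. The step it made is a step that the two limits leave unreadable from compound 2 to compound 1, so its size cannot be read from these two limits. Compound 3 shares the same kind of right-hand group as compound 2, but the difference between the two cores is not broken down here.

Compound 4, `O=C(NCCNS(=O)(=O)c1ccc(-c2ccccc2Oc2ccc(O)c(O)c2)s1)Nc1cc(C(F)(F)F)cc(C(F)(F)F)c1`, is not yet measured. It differs from compound 3 by 3,4-dihydroxyphenyl in place of 3,4-dinitrophenyl on an oxygen on an aromatic ring, the same change as from compound 2 to compound 1, at the same place. For the measured compounds named here, because of the limit of > 20000 nM in this assay, at which 2 of the 3 values shown sit, and (the limit of > 50000 nM in this assay, at which 1 of the 3 values shown sits), the three known values give no direction for this step. For compound 4 the expected step is a step that the limit leaves unreadable from compound 3 to compound 4. Compound 4 is estimated at 60000 nM, expected to fall between 15000 nM and 250000 nM, most likely again as a limit.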

Compound 4, half-maximal inhibitory concentration: > 20000 nM
Compound 4 was reported as a limit; the forecaster's own chance of this, stated with the estimate: 85%; the middle value is on the limit's open side.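

Compound 3 and compound 4 are both reported in this assay only as limits of the assay, not as numbers, and the step between them cannot be read. The compounds shown leave open how strongly any of the four inhibits, and whether 3,4-dihydroxyphenyl or 3,4-dinitrophenyl on this shared core gives the stronger inhibitor.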